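The compounds below may be only part of what the source reports. "The series", "measured", "known", "first", "only" and "open" are said of these compounds alone.

Compound 1 `Cc1ccc2nc(-c3ccccc3N(C)C)[nH]c(=O)c2c1` carries a dimethylamino group on its outer ring and a methyl on its core. In an assay on isolated protein for inhibition of DNA topoisomerase 1 (Homo sapiens), with a stated time of 30 min, tested at 100 uM (on this read-out lower numbers stand for a weaker effect and higher numbers for a stronger effect at the one concentration tested), compound 1 gives 82.9%. Compound 2 `Cc1ccc2nc(-c3ccccc3C(F)(F)F)[nH]c(=O)c2c1` differs from compound 1 only by trifluoromethyl in place of dimethylamino on an aromatic carbon. In this assay compound 2 gives 72%, and the step is a number 10.9 percentage points lower from compound 1 to compound 2 (beyond the scatter). Compound 3 `CCN(CC)c1ccc2nc(-c3ccccc3N(C)C)[nH]c(=O)c2c1` keeps the dimethylamino group but changes the core through (diethylamino in place of methyl on an aromatic carbon). In this assay compound 3 gives 82.1%, a step of a number 0.8 percentage points lower from compound 1 to compound 3 (within the scatter), so the core change by itself leaves the inhibition essentially where it was.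

Compound 4 `CCN(CC)c1ccc2nc(-c3ccccc3C(F)(F)F)[nH]c(=O)c2c1` has not yet been measured. It is built from compound 3 through (trifluoromethyl in place of dimethylamino on an aromatic carbon), the same change that led from compound 1 to compound 2, at a place described in the same words in both cases. Because the earlier step was a number 10.9 percentage points lower from compound 1 to compound 2 (beyond the scatter) while the core change gave only a number 0.8 percentage points lower from compound 1 to compound 3 (within the scatter), a similar step is expected here, namely a number 10.1 percentage points lower from compound 3 to compound 4 (beyond the scatter). On that basis compound 4 is estimated at 72%, most likely between 60% and 82%.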

Compound 4, a percentage reported as inhibition, at one concentration (the size of the read-out at that concentration, not a potency): 81.7%
Estimate against measurement, compound 4: 9.7 percentage points below; low and high end bracket the measured number.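

On the core with diethylamino, trifluoromethyl in place of dimethylamino gives a number 0.4 percentage points lower from compound 3 to compound 4 (within the scatter) in this assay, and this step cannot be told apart from the one seen on the core with methyl: the same change on two cores in this assay, a number 10.9 percentage points lower (beyond the scatter) from compound 1 to compound 2 and a number 0.4 percentage points lower (within the scatter) from compound 3 to compound 4, 10.5 percentage points apart, within the scatter of two such steps. Read the other way, diethylamino in place of methyl gives a number 9.7 percentage points higher from compound 2 to compound 4 (within the scatter) with trifluoromethyl on the outer ring, and this step likewise cannot be told apart from the same core change made with dimethylamino there: the same change on two cores in this assay, a number 0.8 percentage points lower (within the scatter) from compound 1 to compound 3 and a number 9.7 percentage points higher (within the scatter) from compound 2 to compound 4, 10.5 percentage points apart, within the scatter of two such steps. These two pairs therefore do not show that the effect of the swap depends on the core, but they do not show that it carries over unchanged either, since one step lies beyond the scatter and the other within it.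

The compounds shown leave open how a nitrile or a methoxy group on the outer ring would behave on either core. They also leave open whether a pyrrolidine or a longer chain on the core would give the same picture.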